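Swapping oxan-4-yl for isopropyl on the kinase inhibitor core

The source may hold more compounds than are shown below. What is called first, only, known or untested is meant among the compounds shown, and "the series" means these compounds.

In an assay on isolated protein for inhibition of serine/threonine-protein kinase PLK1 (Homo sapiens), read by Z'-LYTE (on this read-out lower numbers stand for stronger inhibition and higher numbers for weaker inhibition), compound 1 `COc1cc(C(=O)NC2CCN(C)CC2)ccc1Nc1ncc2c(n1)N(C(C)C)[C@H](C)C(=O)N2C` gives 25.2 nM, while compound 2 `COc1cc(C(=O)NC2CCN(C)CC2)ccc1Nc1ncc2c(n1)N(C1CCOCC1)[C@H](CC(C)C)C(=O)N2C` gives 322 nM, the higher of the two numbers and well beyond the scatter from compound 1. Compound 3 `COc1cc(C(=O)NC2CCN(C)CC2)ccc1Nc1ncc2c(n1)N(C(C)C)[C@H](CC(C)C)C(=O)N2C` differs from compound 2 by isopropyl in place of oxan-4-yl on a nitrogen on an aromatic ring in a ring. For the measured compounds named here, no step between measured compounds isolates this change, since compound 1 also carries methyl rather than isobutyl. Compound 3 is expected near 120 nM, between 40 nM and 400 nM. This estimate means an expected step of a 2.7-fold lower number from compound 2 to compound 3 (0.43 log units; beyond the scatter), toward stronger inhibition.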

Compound 3, half-maximal inhibitory concentration: 218 nM
Compound 3: middle estimate off by 1.8-fold (0.26 log units), on the low side, within the range that was stated.
By their numbers in this assay, from the lowest: compound 1; then compounds 3 and 2 (each within the scatter of the next).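

In this assay, isopropyl in place of oxan-4-yl on this nitrogen gives a 1.5-fold lower number from compound 2 to compound 3 (0.17 log units; within the scatter), so with the isobutyl group present, the compounds do not separate at this position despite the loss of the ring and its oxygen. The change beyond the scatter lies elsewhere: isobutyl in place of methyl gives an 8.7-fold higher number from compound 1 to compound 3 (0.94 log units; beyond the scatter). Nothing available explains either step. From the compounds shown here alone, it remains open whether oxan-4-yl would be tolerated equally alongside the methyl group, and how a cyclopentyl or piperidin-4-yl group on this nitrogen would read.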